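A few compounds are considered here, and "the series" means these few. Any claim that something is new, unique, unknown or untested is made for them only; others in the source may bear on it.

Compound 3 `COc1ccc(NC(=O)c2cc(Oc3ccc(/C=C/c4ccncc4)cc3)ccn2)cc1` is the point of departure. In a functional assay on HepG2 cells (Homo sapiens) for antiproliferative activity, read by CCK-8 assay, with a stated time of 48 h (on this read-out higher numbers stand for weaker inhibition and lower numbers for stronger inhibition), compound 3 gives > 100000 nM, which is a limit of the assay rather than a number. Among the three measured compounds, compound 3 alone sits at that limit, as shown by the limit of > 100000 nM in this assay, at which 1 of the 3 values shown sits. Compound 1 `COc1ccc(NC(=O)c2cc(Oc3ccc(/C=C/c4ccccn4)cc3)ccn2)cc1` carries pyridin-2-yl in place of the pyridin-4-yl of compound 3. In this assay compound 1 gives 30000 nM, and the step of an at least 3.3-fold higher number from compound 1 to compound 3 (0.52 log units; beyond the scatter) is beyond the scatter.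

Compound 4 `O=C(NC1CCCCC1)c1cc(Oc2ccc(/C=C/c3ccncc3)cc2)ccn1` differs from compound 3 in one place: cyclohexyl in place of 4-methoxyphenyl on an amide-type nitrogen. For the measured compounds named here, the measured step that bears on an exchange at the amide nitrogen is the one from compound 1 to compound 2 `O=C(c1cc(Oc2ccc(/C=C/c3ccccn3)cc2)ccn1)N1CCCC1`, which gives 27000 nM in this assay; that step, a 1.1-fold lower number from compound 1 to compound 2 (0.05 log units; within the scatter), lies within the scatter. The amide substituent therefore has shown no effect beyond the scatter in the one case where it was varied, and the pyridin-4-yl arrangement of compound 3 remains in compound 4.

Compound 4 is thus expected to stay close to where compound 3 stands, with an expected step of a number no higher from compound 3 to compound 4 (the limit leaves the size open). The estimate for compound 4 in this assay is 100000 nM, with a range from 40000 nM to 300000 nM, and it is quite possible that only a limit will again be reported.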

Compound 4, half-maximal inhibitory concentration: 22400 nM
Compound 4: middle estimate off by 4.5-fold (0.65 log units), on the high side; the measured number lies below the stated range.
By their numbers in this assay, from the lowest: compounds 4, 2 and 1 (each within the scatter of the next). At a limit, above all of these: compound 3.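

In this assay, for the compounds shown here, the amide nitrogen now shows an effect that the earlier compounds did not: with pyridin-4-yl kept in place, cyclohexyl in place of 4-methoxyphenyl gives an at least 4.4-fold lower number from compound 3 to compound 4 (0.64 log units; beyond the scatter). Going by these compounds alone, the one earlier exchange at this nitrogen, with pyridin-2-yl kept in place and pyrrolidin-1-yl entering, gave a 1.1-fold lower number from compound 1 to compound 2 (0.05 log units; within the scatter), so the group on the amide nitrogen is no longer without a measured effect in every case, although that earlier step involved a different entering group on a different background. The new step has an open size, and its true extent cannot be read because compound 3 stands at a limit of the assay: the limit of > 100000 nM in this assay, at which 1 of the 4 values shown sits.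

The compounds shown leave open whether cyclohexyl would also lower the number with pyridin-2-yl on the double-bonded chain, and so whether the effect of the amide substituent depends on how the pyridine is attached. They also leave open whether the non-aromatic carbon ring itself is needed, or whether an open chain such as n-hexyl, or a ring carrying an amine, such as piperidin-4-yl, would serve in its place on the amide nitrogen.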